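This account rests on a few compounds, and the source may have more. Where it says the series, first, only, none or still open, it means among the compounds named here.

The shared core of compound 3 `COc1ccc(/C=C2\CCC/C(=C\c3cccc(Cl)c3)C2=O)cc1OC` carries two benzylidene arms on a cyclohexanone. Its companions are compound 1 `COc1cccc(/C=C2\CCC/C(=C\c3ccc(Cl)cc3Cl)C2=O)c1OC`, compound 2 `COc1cccc(/C=C2\CCC/C(=C\c3cc(Cl)cc(Cl)c3)C2=O)c1OC` and compound 4 `COc1ccc(/C=C2\CCC/C(=C\c3ccc(Cl)c(Cl)c3)C2=O)cc1OC`, which has not yet been measured. In a functional assay on MCF7 cells (Homo sapiens) for cytotoxicity, read by MTT assay, with a stated time of 72 h (on this read-out higher numbers stand for weaker inhibition and lower numbers for stronger inhibition), compound 1 gives only a limit of the assay, > 20000 nM, and not a number (the limit of > 20000 nM in this assay, at which 1 of the 3 values shown sits). In this assay compound 2 gives 4300 nM. Compound 3 stands with the highest of the two real numbers, giving 6000 nM in this assay, though its gap to compound 2 lies within the scatter. Among the measured compounds shown here, the only measured step, an at least 4.6-fold lower number from compound 1 to compound 2 (0.66 log units; beyond the scatter), shows that moving chlorines around this ring can matter. From compound 3 to compound 4 the change is chloro in place of hydrogen on an aromatic carbon. That step places a chloro para to the large group, a pattern shared with compound 1, so a modest rise in the number is expected, a 1.5-fold higher number from compound 3 to compound 4 (0.18 log units; within the scatter), with a fair chance the result is only a limit. Compound 4 is therefore estimated at 9000 nM, between 3000 nM and 25000 nM.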

Compound 4, half-maximal inhibitory concentration: 4400 nM
Beside the measured number, compound 4's estimate is 2.0-fold (0.31 log units) above it; the measured number falls inside the stated range.
By their numbers in this assay, from the lowest: compounds 2, 4 and 3 (each within the scatter of the next). At a limit, above all of these: compound 1.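

In this assay the added chloro gives a 1.4-fold lower number from compound 3 to compound 4 (0.13 log units; within the scatter) and so the 3-chlorophenyl and 3,4-dichlorophenyl arms cannot be told apart at this position, para to a large group. Among the compounds shown here, the only earlier step gave an at least 4.6-fold lower number from compound 1 to compound 2 (0.66 log units; beyond the scatter) on rearranging two chloro groups, whereas this step adds one chloro to an arm that already holds one, and here the extra atom shifts nothing beyond the scatter. Nothing measured here offers a reason for this result.

The compounds shown leave open whether an amine or a carboxylic acid at this same place would stay within the scatter of compound 3 or move the number clearly. They also leave open whether the same added chloro would behave alike with the methoxy groups placed as in compound 1 and compound 2 on the other arm.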